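The source may hold more compounds than are shown below. What is called first, only, known or untested is meant among the compounds shown, and "the series" means these compounds.

Measured so far:
Compound 1 `O=S(=O)(c1cc(Cl)cc(Cl)c1)c1cnc2cc(F)ccc2c1-c1ccc(F)cc1` in an ADME assay on microsomes from liver (Homo sapiens) for metabolic stability, tested at 2.5 uM (a lower number here means slower removal, a higher number faster removal of the compound), gives 0.18 mL/min.
Compound 2 `COc1ccc(S(=O)(=O)c2cnc3cc(F)ccc3c2-c2ccc(F)cc2)cc1Cl` in this assay gives 1.29 mL/min.

Going by the values given here, compound 2 holds the higher of the two numbers measured in this assay; its only neighbour is compound 1, separated from it by the step of a 7.2-fold higher number from compound 1 to compound 2 (0.86 log units; beyond the scatter). Compound 3 `COc1ccc(S(=O)(=O)c2cnc3cc(F)ccc3c2-c2ccc(F)cc2)cc1` is not yet measured. It differs from compound 2 by hydrogen in place of chloro on an aromatic carbon. Among the compounds with values here, one measured step touches the same ring, the swap of 3,5-dichlorophenyl for 3-chloro-4-methoxyphenyl on the sulfonyl sulfur, and it read a 7.2-fold higher number from compound 1 to compound 2 (0.86 log units; beyond the scatter). Within the data shown here, that step changed two substituents at once, and no measured pair isolates the loss of a single chloro, so the direction for compound 3 cannot be read from the data with confidence. The expectation is a step of a 1.2-fold higher number from compound 2 to compound 3 (0.07 log units; within the scatter) that stays within the usual scatter. For compound 3 the estimate in this assay is 1.5 mL/min with a range of 0.6 mL/min to 3.5 mL/min.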

Compound 3, intrinsic clearance in a liver preparation (reported as CLH), per the amount of preparation that the assay uses: 1.71 mL/min
Compound 3: middle estimate off by 1.1-fold (0.06 log units), on the low side, and the stated range covers the measured number.
By their numbers in this assay, from the lowest: compound 1; then compounds 2 and 3 (each within the scatter of the next).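

In this assay the step from 3-chloro-4-methoxyphenyl to 4-methoxyphenyl reads a 1.3-fold higher number from compound 2 to compound 3 (0.12 log units; within the scatter) and so leaves compound 2 and compound 3 indistinguishable: the chloro ortho to the methoxy group, taken alone, has no effect here that repeat measurements could separate from noise. Compound 1 stands apart from both, with a 7.2-fold higher number from compound 1 to compound 2 (0.86 log units; beyond the scatter) and with a 9.5-fold higher number from compound 1 to compound 3 (0.98 log units; beyond the scatter) for the swap from 3,5-dichlorophenyl to 4-methoxyphenyl, so the gap opened by the earlier step persists without that chloro. No available data explain this gap.

Still open is whether the gap follows the methoxy group or the loss of the 3,5-dichloro pattern, since no compound shown carries a plain phenyl on the sulfonyl sulfur. As far as these compounds go, how an amine or a carboxylic acid in place of the methoxy group would read in this assay also remains unknown.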